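The compounds below may be only part of what the source reports. "The series", "measured", "known", "first", "only" and "open" are said of these compounds alone.

Measured in a functional assay on HepG2 cells (Homo sapiens) for antiproliferative activity, read by MTT assay, with a stated time of 48 h; on this read-out higher numbers stand for weaker inhibition and lower numbers for stronger inhibition:
compound 1 `Clc1cccc(Nc2ncnc3ccc(NCc4cccc(Br)n4)cc23)c1` — 3870 nM
compound 2 `Clc1cccc(Nc2ncnc3ccc(NCc4ccc(Br)s4)cc23)c1` — 3110 nM
compound 3 `O=C(/C=C/c1ncc2ccccc2n1)Nc1ccc2ncnc(Nc3cccc(Cl)c3)c2c1` — 7790 nM

The number for compound 3 is the largest of the three, but set against compound 1 the difference lies within the scatter; only against compound 2 does it lie beyond it, so compound 3 is not separated from the whole set.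

Compound 4 `O=C(/C=C/c1cccnc1Cl)Nc1ccc2ncnc(Nc3cccc(Cl)c3)c2c1` is the open compound. It differs from compound 3 by 2-chloropyridin-3-yl in place of quinazolin-2-yl on a double-bonded chain carbon bound to a double-bonded chain carbon. Among the compounds with values here, the one measured step, a 1.2-fold lower number from compound 1 to compound 2 (0.09 log units; within the scatter), is the only guide: it also exchanges one pendant aromatic heterocycle for another, though on a saturated chain carbon bound to a ring nitrogen rather than on the double-bonded chain carbon changed here. That step left the read-out unchanged within the scatter. Within the data shown here, there is no measured example of a change at the position altered between compound 3 and compound 4, so nothing supports a directional call.

Compound 4 is therefore expected to sit close to compound 3, with an estimated step of a 1.1-fold lower number from compound 3 to compound 4 (0.05 log units; within the scatter) in this assay, not beyond the scatter in either direction. The estimate for compound 4 is 7000 nM, within a range from 2500 nM to 20000 nM.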

Compound 4, half-maximal inhibitory concentration: 4420 nM
Compound 4: middle estimate off by 1.6-fold (0.20 log units), on the high side; measured number inside the range.
By their numbers in this assay, from the lowest: compounds 2, 1, 4 and 3 (each within the scatter of the next, the first and the last beyond it).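

In this assay, within the data shown here, the exchange on a double-bonded chain carbon bound to a double-bonded chain carbon gives a 1.8-fold lower number from compound 3 to compound 4 (0.25 log units; within the scatter), the first reading of any change at this place. One six-membered aromatic ring with 1 hetero atom and a chlorine, as 2-chloropyridin-3-yl, thus stands in for the quinazolin-2-yl group and its two aromatic rings without a separation in the read-out beyond the scatter, so across this pair the size of the group and the number of ring nitrogens are not shown to matter. No measurement is at hand that would explain this result or tie it to any feature of either group.

The compounds shown hold only these two aromatic groups at this place, so the part played by the chlorine cannot be separated from that of the pyridine ring, and a plain pyridin-3-yl or a phenyl group would be needed to split them. On these data alone, whether a non-aromatic group such as morpholine or a dimethylamine is accepted at this place also stays open, as does any effect of the amide link itself.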